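An Amino Group Added Twice: One Step Measured, One Expected

The source may report more compounds than this note shows. Statements on the series, on what has been measured and on what is new or still open speak of the compounds shown alone.

Compound 1, `ClCc1ccc(Cn2cnc3c(Cl)ncnc32)cc1`, gives 74100 nM in a functional assay on SK-MEL-5 cells (Homo sapiens) for cytotoxicity, read by sulforhodamine B assay, with a stated time of 48 h; a higher number here means that more compound is tolerated, a lower number that less compound is tolerated.
Compound 2, `Nc1nc(Cl)c2ncn(Cc3ccc(CCl)cc3)c2n1`, gives 63100 nM in this assay.
Compound 3, `ClCc1ccccc1Cn1cnc2c(Cl)ncnc21`, gives 5880 nM in this assay.

Compound 1 and compound 2 share a core, and compound 2 differs from compound 1 by a single change: amino in place of hydrogen on an aromatic carbon. That change produced the step of a 1.2-fold lower number from compound 1 to compound 2 (0.07 log units; within the scatter), so the two numbers are, for practical purposes, alike. Compound 3 is built from the same atoms as compound 1 but joined differently; the difference between the two cores is not broken down here. In this assay compound 3 gives the lowest number of the three, and the gaps to compound 2 and to compound 1 are both clearly beyond the scatter, so less of compound 3 is tolerated than of either of the others.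

Compound 4, `Nc1nc(Cl)c2ncn(Cc3ccccc3CCl)c2n1`, has not yet been measured. It stands to compound 3 exactly as compound 2 stands to compound 1: amino in place of hydrogen on an aromatic carbon. It is the same change at the same place. A step of similar size is expected here, a 1.2-fold lower number from compound 3 to compound 4 (0.07 log units; within the scatter), resting on the earlier step of a 1.2-fold lower number from compound 1 to compound 2 (0.07 log units; within the scatter). Since this rests on a single pair, the expectation is held loosely. Compound 4 is estimated at 5000 nM in this assay, with a likely range from 2000 nM to 12500 nM.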

Compound 4, concentration lethal to 50% of the cells: 75900 nM
Beside the measured number, compound 4's estimate is 15-fold (1.18 log units) below it, outside the stated range (above it).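

In this assay, amino in place of hydrogen on an aromatic carbon gives a 13-fold higher number from compound 3 to compound 4 (1.11 log units; beyond the scatter), so on the core of compound 3 this small change means that much more of the compound is tolerated. Set beside the earlier step, the same change at the same place does not carry over from one core to the other, and its effect here depends on the core that bears it: the same change on two cores in this assay, a 1.2-fold lower number (0.07 log units; within the scatter) from compound 1 to compound 2 and a 13-fold higher number (1.11 log units; beyond the scatter) from compound 3 to compound 4, 15-fold (1.18 log units) apart, beyond the scatter of two such steps. This does not show why the two cores answer so differently, and with a single pair on each core it offers no rule for a third core in this series, only a warning that a step seen on one core cannot be assumed on another.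

The compounds shown leave open whether a different group in place of that hydrogen, such as a hydroxyl or a methylamino group, would split between the two cores in the same way or would give similar steps on both. They also leave open whether the split would survive if the chloro group on the same ring gave way to a methoxy group.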